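A Methyl Added to the Ring of Compound 3

A few compounds are considered here, and "the series" means these few. Any claim that something is new, unique, unknown or untested is made for them only; others in the source may bear on it.

Compound 1 `CC1=CC[C@@H]([C@@](C)(O)CCCC(C)(C)NC=S)CC1` was tested in a functional assay on UACC-62 cells (Homo sapiens) for cytotoxicity, read by sulforhodamine B assay; a lower number here means that less compound is tolerated, a higher number that more compound is tolerated; compound 1 reaches only the limit > 100000 nM. Compound 2 `CC1=CC[C@@H]([C@@](C)(O)CCCC(C)(C)NC(=S)NN)CC1` likewise reaches only the limit > 100000 nM. Among the measured compounds shown here, compound 3 `CC1=CC[C@@H]([C@@](C)(O)CCCC(C)(C)NC(=S)N/N=C\c2ccccc2)CC1` gives 48400 nM, the single number among the three. The two other values stand at a boundary of the assay (the limit of > 100000 nM in this assay, at which 2 of the 3 values shown sit). The steps of an at least 2.0-fold lower number from compound 1 to compound 3 (0.31 log units; beyond the scatter) and an at least 2.0-fold lower number from compound 2 to compound 3 (0.31 log units; beyond the scatter) both show the larger group at the thiocarbonyl end lowering the number. For the measured compounds named here, compound 4 `CC1=CC[C@@H]([C@@](C)(O)CCCC(C)(C)NC(=S)N/N=C\c2ccc(C)cc2)CC1` differs from compound 3 by methyl in place of hydrogen on an aromatic carbon, a change on the ring that none of the measured steps probe directly. No step beyond the scatter is therefore expected in this assay, and the step of a 1.2-fold lower number from compound 3 to compound 4 (0.08 log units; within the scatter) is estimated. Compound 4 is expected to give 40000 nM, with a range from 15000 nM to 100000 nM.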

Compound 4, concentration lethal to 50% of the cells: 52300 nM
For compound 4 the middle estimate is 1.3-fold (0.12 log units) below the measured one; the range from low to high includes it.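

In this assay, the change from phenyl to 4-methylphenyl gives a 1.1-fold higher number from compound 3 to compound 4 (0.03 log units; within the scatter), so a methyl on this aromatic carbon, para to a large group, leaves the number unresolved from that of compound 3. The step of an at least 1.9-fold lower number from compound 2 to compound 4 (0.28 log units; that floor lies within the scatter) gives only a floor, because compound 2 stands at a limit: the limit of > 100000 nM in this assay, at which 2 of the 4 values shown sit.

From the compounds shown here alone, what stays open is whether a group other than methyl at this place, such as an amine, a carboxylic acid or a longer chain, would shift the number beyond the scatter.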